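The compounds below may be only part of what the source reports. "The series", "measured", "known", "first", "only" and "open" are said of these compounds alone.

Compound 1 `COc1cc(-n2cnc3ccc(-c4ccc(C)cc4)cc32)cc(OC)c1OC` gives 110 nM
Compound 2 `COc1ccc(-c2ccc3ncn(-c4cc(OC)c(OC)c(OC)c4)c3c2)cc1` gives 210 nM

Both numbers come from a functional assay on MCF7 cells (Homo sapiens) for antiproliferative activity, read by MTT assay, with a stated time of 72 h (on this read-out higher numbers stand for weaker inhibition and lower numbers for stronger inhibition), where compound 2 at 210 nM stands within the scatter of compound 1 and the two cannot be ranked. Compound 3 `COc1cc(-n2cnc3ccc(-c4ccc(O)cc4)cc32)cc(OC)c1OC` carries 4-hydroxyphenyl where compound 2 carries 4-methoxyphenyl. The change is hydrogen in place of methyl on an oxygen on an aromatic ring and amounts to hydrogen in place of methyl on an oxygen on an aromatic ring. For the measured compounds named here, only one measured step touches this group, methoxy in place of methyl on an aromatic carbon, and it is a 1.9-fold higher number from compound 1 to compound 2 (0.28 log units; within the scatter) in this assay as measured. Going by the values given here, no measured step removes the methyl from that oxygen, so the data give no direction, and no step beyond the scatter is expected. The estimate amounts to an expected 1.1-fold lower number from compound 2 to compound 3 (0.02 log units; within the scatter) in this read-out. For compound 3 the expected value is 200 nM with an estimated range from 70 nM to 600 nM in all.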

Compound 3, half-maximal inhibitory concentration: 4160 nM
Compound 3: the middle estimate sits 21-fold (1.32 log units) below what was measured; the measured number lies above the stated range.
By their numbers in this assay, from the lowest: compounds 1 and 2 (each within the scatter of the next); then compound 3.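

Until now the group on this phenyl ring had seemed to make little difference in this assay, since methyl and methoxy could not be told apart. That picture does not extend to hydroxy: hydrogen in place of methyl on the oxygen gives a 20-fold higher number from compound 2 to compound 3 (1.30 log units; beyond the scatter), and hydroxy in place of methyl on the aromatic carbon gives a 38-fold higher number from compound 1 to compound 3 (1.58 log units; beyond the scatter), so this position does respond to the group it carries, and the methyl on the oxygen of compound 2 cannot be removed without a large loss in this assay. Nothing given here accounts for the size of this loss.

With only these three groups at the position, the compounds leave open whether the loss is particular to hydroxy. An amine or a carboxylic acid there might follow compound 3, or might instead stay with compound 1 and compound 2.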